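Three Limits and a Trifluoromethyl Analogue

The compounds below may be only part of what the source reports. "The series", "measured", "known", "first", "only" and "open" are said of these compounds alone.

Compound 1 `OC[C@H]1O[C@@H](n2cnc3c(NCc4cccc(Br)c4)ncnc32)[C@H](O)[C@@H]1O` carries a 3-bromophenyl group on a saturated chain carbon bound to a nitrogen on an aromatic ring. In a functional assay on MCF cells (Homo sapiens) for antiproliferative activity, with a stated time of 72 h (on this read-out higher numbers stand for weaker inhibition and lower numbers for stronger inhibition), compound 1 reaches only the limit of the assay, > 166000 nM. Compound 2 `COc1ccc(CNc2ncnc3c2ncn3[C@@H]2O[C@H](CO)[C@@H](O)[C@H]2O)c(OC)c1` bears 2,4-dimethoxyphenyl at the same place, and in this assay compound 2 likewise gives only a limit, > 166000 nM. Compound 3 `OC[C@H]1O[C@@H](n2cnc3c(NCc4ccc(F)c(F)c4F)ncnc32)[C@H](O)[C@@H]1O` has 2,3,4-trifluorophenyl there; in this assay compound 3 also stops at a limit, > 166000 nM. Compound 3 thus stands with the other two at the limit of > 166000 nM in this assay, at which 3 of the 3 values shown sit, and the steps a step that the two limits leave unreadable from compound 1 to compound 2, a step that the two limits leave unreadable from compound 1 to compound 3 and a step that the two limits leave unreadable from compound 2 to compound 3 cannot be read in size or direction. Compound 4 `OC[C@H]1O[C@@H](n2cnc3c(NCc4cccc(C(F)(F)F)c4)ncnc32)[C@H](O)[C@@H]1O` differs from compound 3 as follows: 3-(trifluoromethyl)phenyl in place of 2,3,4-trifluorophenyl on a saturated chain carbon bound to a nitrogen on an aromatic ring. From the compounds shown here alone, the three measured steps bear on this change only in showing that no aryl variant so far escaped the limit; their sizes are unknown. No step beyond the scatter is therefore expected for a step that the limit leaves unreadable from compound 3 to compound 4. Compound 4 is estimated at 200000 nM, with a range from 80000 nM to 600000 nM, and is expected most likely to be reported again only as a limit.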

Compound 4, half-maximal inhibitory concentration: > 166000 nM
Compound 4: no number, only a limit; the forecaster's own chance of this, stated with the estimate: 85%; the middle value does not contradict the limit.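

In this assay, among these compounds, compound 4 also gives only a limit (> 166000 nM), so no step between compound 4 and compound 1, compound 2 or compound 3 can be read. The compounds shown leave open how these four aryl groups rank in this assay and whether any of them differs from the others at all.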